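Indazole for tolyl on the shared core

The source may hold more compounds than are shown below. What is called first, only, known or untested is meant among the compounds shown, and "the series" means these compounds.

Measured so far:
compound 1 `COc1cc(-c2ccnc3cc(-c4ccc(C)cc4)nn23)cc(OC)c1OC` — 21 nM
compound 2 `Cn1ccc2cc(-c3cc4nccc(-c5ccc(F)cc5)n4n3)ccc21` — 4780 nM
compound 3 `COc1cc(-c2ccnc3cc(-c4ccc5c(ccn5C)c4)nn23)cc(OC)c1OC` — 48 nM

In a functional assay on B16-F0 cells (Mus musculus) for inhibition, read by CCK-8 assay, with a stated time of 48 h (on this read-out higher numbers stand for weaker inhibition and lower numbers for stronger inhibition), compound 1 gives the lowest number of the three. Its nearest neighbour is compound 3, and the step of a 2.3-fold higher number from compound 1 to compound 3 (0.36 log units; beyond the scatter) is modest but beyond the scatter. Compound 2, which differs from compound 1 at more than one place, sits far higher, and both of those values stand as they are without a single-change step between them.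

Compound 4 `COc1cc(-c2ccnc3cc(-c4ccc5cnn(C)c5c4)nn23)cc(OC)c1OC` is not yet measured. It differs from compound 1 by 1-methyl-1H-indazol-6-yl in place of 4-methylphenyl on an aromatic carbon. Within the data shown here, the one step that bears on this change is the exchange of the same 4-methylphenyl for a fused bicyclic aromatic group, 1-methyl-1H-indol-5-yl, in compound 3: a 2.3-fold higher number from compound 1 to compound 3 (0.36 log units; beyond the scatter). The 1-methyl-1H-indazol-6-yl group in compound 4 is likewise a fused two-ring aromatic group in place of 4-methylphenyl, so in this assay a step of similar size and direction is expected, a modest rise in the number, though a result within the scatter cannot be excluded. Compound 4 is therefore estimated at 45 nM, with a range of 15 nM to 150 nM, which means an expected step of a 2.1-fold higher number from compound 1 to compound 4 (0.33 log units; beyond the scatter).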

Compound 4, half-maximal inhibitory concentration: 1000 nM
Compound 4: middle estimate off by 22-fold (1.35 log units), on the low side; the measured number lies above the stated range.
By their numbers in this assay, from the lowest: compound 1; then compound 3; then compound 4; then compound 2.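

In this assay this position, on an aromatic carbon next to the ring nitrogen, does not accept every two-ring aromatic group alike: 1-methyl-1H-indazol-6-yl in place of 4-methylphenyl gives a 48-fold higher number from compound 1 to compound 4 (1.68 log units; beyond the scatter), a large step, against the modest 2.3-fold higher number from compound 1 to compound 3 (0.36 log units; beyond the scatter) for 1-methyl-1H-indol-5-yl. The difference between the two two-ring groups is itself large, at a 21-fold higher number from compound 3 to compound 4 (1.32 log units; beyond the scatter), so the earlier step from 4-methylphenyl to 1-methyl-1H-indol-5-yl cannot be read as a general allowance for a larger group here. No measurement bears on why the number rises so far with 1-methyl-1H-indazol-6-yl.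

Compound 3 and compound 4 differ both in the ring atoms of the five-membered ring and in the point of attachment, so the step between them does not separate the two changes; 1-methyl-1H-indol-6-yl and 1-methyl-1H-indazol-5-yl, which would pull them apart, are not among the compounds shown. Going by these compounds, whether a single-ring group such as a 4-methoxyphenyl or a 4-aminophenyl at this position stays near compound 1 also remains open.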